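The compounds below may be only part of what the source reports. "The series", "measured", "known", "first", "only" and "open" are said of these compounds alone.

Compound 1 `O=C1c2c[n+]([O-])c3ccccc3c2C(=O)c2c1c1ccccc1n2Cc1cn([C@@H]2C[C@H](O)[C@@H](CO)O2)nn1` carries a sugar-like ring on a triazole nitrogen. In a functional assay on MCF7 cells (Homo sapiens) for cytotoxicity, read by MTT assay, with a stated time of 72 h (a higher number here means a weaker inhibitor, a lower number a stronger inhibitor), compound 1 gives 110 nM, the lowest of the three numbers measured. Compound 3 `O=C1c2c[n+]([O-])c3ccccc3c2C(=O)c2c1c1ccccc1n2CCCCN1CCCCC1`, which bears a chain ending in a saturated nitrogen ring, gives 150 nM; these two values lie within the usual scatter of each other. Compound 2 `CC1(C)OCC(Cn2cc(Cn3c4c(c5ccccc53)C(=O)c3c[n+]([O-])c5ccccc5c3C4=O)nn2)O1` gives 290 nM, and the step of a 2.6-fold higher number from compound 1 to compound 2 (0.42 log units; beyond the scatter) is the only one that separates clearly from the others.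

Compound 4 `O=C1c2c[n+]([O-])c3ccccc3c2C(=O)c2c1c1ccccc1n2Cc1cn(C[C@@H](O)CO)nn1` is not yet measured. It differs from compound 1 as follows: 2,3-dihydroxypropyl in place of 4-hydroxy-5-(hydroxymethyl)oxolan-2-yl on an aromatic nitrogen. Going by the values given here, the one step that bears on this change is a 2.6-fold higher number from compound 1 to compound 2 (0.42 log units; beyond the scatter), where the ring was likewise exchanged for a smaller, acyclic-linked group on the same nitrogen, with a modest loss. Compound 4 keeps the two hydrogen-bond donors of the ring that leaves, so a smaller loss than that, or none beyond the scatter, is expected: a 1.8-fold higher number from compound 1 to compound 4 (0.26 log units; within the scatter). Compound 4 is therefore expected to give about 200 nM, between 90 nM and 450 nM.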

Compound 4, half-maximal inhibitory concentration: 600 nM
The estimate for compound 4 lay 3.0-fold (0.48 log units) below the measured number; the whole stated range lies below it.
By their numbers in this assay, from the lowest: compounds 1, 3 and 2 (each within the scatter of the next, the first and the last beyond it); then compound 4.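

In this assay, the 2,3-dihydroxypropyl group has the same count of hydrogen-bond donors as the 4-hydroxy-5-(hydroxymethyl)oxolan-2-yl group it replaces, yet the result is a 5.5-fold higher number from compound 1 to compound 4 (0.74 log units; beyond the scatter), so that count alone does not preserve the value at this aromatic nitrogen. Opening the ring of the protected group in compound 2 to leave a free 1,2-dihydroxyethyl end gives a 2.1-fold higher number from compound 2 to compound 4 (0.32 log units; beyond the scatter), and the comparison with the quite different side chain of compound 3 gives a 4.0-fold higher number from compound 3 to compound 4 (0.60 log units; beyond the scatter), so among these four compounds the open diol chain stands apart from the other three. Nothing shown explains why this open chain gives the highest number.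

The compounds shown leave open whether the hydroxyl groups or the missing ring matter more, which a plain propyl chain on this nitrogen could help separate. From the compounds shown here alone, how a 2-aminoethyl group or a carboxylic acid would behave here also remains open.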